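The source may report more compounds than this note shows. Statements on the series, on what has been measured and on what is new or still open speak of the compounds shown alone.

For the measured compounds named here, compound 1 `CC[C@H](CCn1cncn1)c1ccccc1` gives 99.8 ug/mL in an ADME assay on RD cells (Homo sapiens) for cytotoxicity, read by MTT assay, with a stated time of 3 days (on this read-out higher numbers stand for lower toxicity in this test and lower numbers for higher toxicity in this test), the higher of the two numbers measured so far. Compound 2 `c1ccc([C@@H](CCn2cncn2)C2CCCCC2)cc1` gives 9.2 ug/mL in this assay, and the step of an 11-fold lower number from compound 1 to compound 2 (1.04 log units; beyond the scatter) shows a larger group on the chain going with a markedly lower number. Compound 3 `Cc1ccc(C[C@H](CCn2cncn2)c2ccccc2)cc1` differs from compound 1 by 4-methylphenyl in place of methyl on a saturated chain carbon, two bonds along the chain from an aromatic carbon. Going by the values given here, this change also enlarges the chain, though at a different carbon, so the one measured step bears on it only loosely. A lower number is therefore expected, a 3.3-fold lower number from compound 1 to compound 3 (0.52 log units; beyond the scatter), somewhat smaller than that measured step. Compound 3 is expected to give 30 ug/mL, with a range from 9 ug/mL to 90 ug/mL.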

Compound 3, half-maximal cytotoxic concentration: 37.8 ug/mL
The estimate for compound 3 lay 1.3-fold (0.10 log units) below the measured number; the measured number falls inside the stated range.
By their numbers in this assay, from the lowest: compound 2; then compound 3; then compound 1.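

Placing 4-methylphenyl in place of methyl on a saturated chain carbon, two bonds along the chain from an aromatic carbon, gives a 2.6-fold lower number from compound 1 to compound 3 (0.42 log units; beyond the scatter) in this assay. This modest step is smaller than an 11-fold lower number from compound 1 to compound 2 (1.04 log units; beyond the scatter), so among these compounds, enlarging the chain does not bring one fixed size of change. No measurement here accounts for the difference between the two steps. From the compounds shown here alone, it remains open whether an unsubstituted phenyl or an amine at this same place would give a similar number.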